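The compounds below may be only part of what the source reports. "The series", "measured", "known", "first", "only" and "open" are said of these compounds alone.

Of the compounds shown here, three have so far been tested in an ADME assay on HepG2 2.2.15 cells (Homo sapiens) for cytotoxicity; on this read-out higher numbers stand for lower toxicity in this test and lower numbers for higher toxicity in this test. Compound 1 `O=C(Nc1ncc(Cc2ccc(Br)cc2)s1)c1ccc2ccccc2c1` reaches only a limit of the assay, > 50000 nM, which is the limit described in the limit of > 50000 nM in this assay, at which 1 of the 3 values shown sits. Compound 2 `O=C(Nc1ncc(C(OCc2ccc(F)cc2Br)c2ccccc2)s1)c1cccs1` is recorded in this assay as "not toxic" (no number reported). Compound 3 `COC(=O)CCCCNc1ncc(C(Oc2ccc3cc(Br)ccc3c2)c2ccc(Cl)cc2)s1` is likewise recorded in this assay as "not toxic" (no number reported), so compound 3 stands without a single number: it sits among entries that are verbal reports of no toxicity or otherwise carry no figure, and none of them pins it to a number. Compound 4 `O=C(Nc1ncc(C(Oc2ccc3cc(Br)ccc3c2)c2ccc(Cl)cc2)s1)c1ccc(Br)cc1` has not yet been measured. It differs from compound 3 in one place ((4-bromophenyl)carbonyl in place of 4-(methoxycarbonyl)butyl on a nitrogen on an aromatic ring). Going by the values given here, no step between two measured compounds is available to show what such a change does in this assay. Every value shown sits at a limit or is reported as not toxic; on that footing the step from compound 3 to compound 4 is expected to stay within the scatter, with no clear direction. Compound 4 is therefore expected to give about 50000 nM in this assay, within an estimated range from 20000 nM to 100000 nM.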

Compound 4, half-maximal cytotoxic concentration: > 50000 nM
Compound 4: only a limit was reported (the forecaster's own chance of this, stated with the estimate: 70%); the middle value lies on the limit itself.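

Compound 3 is reported in this assay as not toxic, without a number. Going by these compounds alone, compound 4 gives > 50000 nM, which is a limit of the assay, so no step from compound 3 to compound 4 can be read. The compounds shown leave open at what concentration, if any, each becomes toxic to these cells, and the values offer no figure to settle this: the limit of > 50000 nM in this assay, at which 2 of the 4 values shown sit.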